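A few compounds are considered here, and "the series" means these few. Any claim that something is new, unique, unknown or untested is made for them only; others in the source may bear on it.

The measured compounds:
compound 1, `C#Cc1cn([C@@H]2O[C@H](CO)[C@@H](O)[C@H]2O)c2ncnc(OC)c12`: 300 nM
compound 2, `Nc1nc2c(c(-c3ccccc3)cn2[C@@H]2O[C@H](CO)[C@@H](O)[C@H]2O)c(=O)[nH]1`: > 20000 nM

Of the compounds shown here, two have been tested in a functional assay on K562 cells (Homo sapiens), read by MTT assay, with a stated time of 72 h; a lower number here means a stronger inhibitor, a higher number a weaker inhibitor. For the measured compounds named here, compound 1 is the only one with a number: in this assay compound 1 gives 300 nM. Going by the values given here, the one further value shown belongs to compound 2: for compound 2 the result in this assay is > 20000 nM, a limit of the assay and not a number, the point at which one of the two values sits (the limit of > 20000 nM in this assay, at which 1 of the 2 values shown sits). Among the compounds with values here, compound 1 and compound 2 differ in more than one place, so no single step joins them; their two values show only that one compound gives a number and the other a limit.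

Compound 3, `COc1ncnc2c1c(-c1cccs1)cn2[C@@H]1O[C@H](CO)[C@@H](O)[C@H]1O`, is not yet measured. It differs from compound 1 by thiophen-2-yl in place of ethynyl on an aromatic carbon. Within the data shown here, no measured pair shows this change, so no size for the step is known from the data. The step from compound 1 to compound 3 is expected to be a loss somewhat beyond the scatter, a 3.3-fold higher number from compound 1 to compound 3 (0.52 log units; beyond the scatter). Compound 3 is therefore estimated at 1000 nM, with a range from 200 nM to 6000 nM.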

Compound 3, half-maximal inhibitory concentration: 70 nM
Compound 3: middle estimate off by 14-fold (1.15 log units), on the high side; the whole stated range lies above it.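

In this assay the aromatic carbon two ring bonds from the ring nitrogen takes a much larger group without any loss: thiophen-2-yl in place of ethynyl gives a 4.3-fold lower number from compound 1 to compound 3 (0.63 log units; beyond the scatter) and so yields the stronger inhibitor of the pair, a step beyond the usual scatter. For the compounds shown here, this is the first single change that can be read, and it shows that the triple bond of the ethynyl group is not required at this carbon for strong inhibition on this core, since a five-membered aromatic ring with one sulfur serves at least as well. Nothing given here accounts for why the thiophen-2-yl group does better at this carbon.

A single replacement on one core cannot show whether the gain belongs to thiophen-2-yl in particular or to aromatic rings at this carbon more generally. Going by these compounds, how an amine, a carboxylic acid or a longer alkyl chain on this carbon would compare remains open, as does whether the step would hold with a change elsewhere on the core.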